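The source may report more compounds than this note shows. Statements on the series, on what has been measured and on what is new or still open speak of the compounds shown alone.

Three compounds have been measured in an in vitro ADME assay on microsomes from liver (Homo sapiens) for metabolic stability, read by LC-MS, tested at 1 uM; a lower number here means slower removal, a higher number faster removal of the compound:
compound 1 `COCCN(C)S(=O)(=O)c1ccc(C)c(C#Cc2cc(Cl)ccc2OCC(=O)O)c1` gives 32 mL.min-1.g-1;
compound 2 `Cc1ccc(S(=O)(=O)N(C)CC(C)C)cc1C#Cc1cc(Cl)ccc1OCC(=O)O` gives 79 mL.min-1.g-1;
compound 3 `Cc1ccc(S(C)(=O)=O)cc1C#Cc1cc(Cl)ccc1OCC(=O)O` gives 14 mL.min-1.g-1.

Compound 3 stands lowest of the three, shown by a 2.3-fold lower number from compound 1 to compound 3 (0.36 log units; beyond the scatter) and a 5.6-fold lower number from compound 2 to compound 3 (0.75 log units; beyond the scatter). Compound 4 `Cc1ccc(S(=O)(=O)N2CCCCC2C)cc1C#Cc1cc(Cl)ccc1OCC(=O)O` is not yet measured; it differs from compound 3 by 2-methylpiperidin-1-yl in place of methyl on a sulfonyl sulfur. The two measured steps onto the sulfonyl sulfur bear on this: read in reverse, moving from methyl to (2-methoxyethyl)(methyl)amino or to isobutyl(methyl)amino raised the number each time, more so with isobutyl(methyl)amino. Since 2-methylpiperidin-1-yl is another such nitrogen-linked group, a rise of comparable size is expected, a 4.3-fold higher number from compound 3 to compound 4 (0.63 log units; beyond the scatter). Compound 4 is therefore estimated at 60 mL.min-1.g-1, within a range of 25 mL.min-1.g-1 to 130 mL.min-1.g-1.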

Compound 4, intrinsic clearance in microsomes: 89 mL.min-1.g-1
Compound 4: the middle estimate sits 1.5-fold (0.17 log units) below what was measured, within the range that was stated.
By their numbers in this assay, from the lowest: compound 3; then compound 1; then compounds 2 and 4 (each within the scatter of the next).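

With a ring closed around the nitrogen, the sulfonyl sulfur still shows a clear rise over methyl in this assay, with a 6.4-fold higher number from compound 3 to compound 4 (0.80 log units; beyond the scatter). The ring form does not separate from the open-chain isobutyl(methyl)amino group, with a 1.1-fold higher number from compound 2 to compound 4 (0.05 log units; within the scatter), while the (2-methoxyethyl)(methyl)amino group stays apart from it, with a 2.8-fold higher number from compound 1 to compound 4 (0.44 log units; beyond the scatter). Nothing available here explains these differences. Still open, as far as these compounds go, is where piperidin-1-yl without its methyl, or a morpholine ring, would fall on this scale. Also open, from the compounds shown here alone, is whether a group as small as dimethylamino already brings the rise.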